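This account rests on a few compounds, and the source may have more. Where it says the series, first, only, none or still open, it means among the compounds named here.

Compounds measured so far:
compound 1 `COc1ccccc1C1C(C#N)=C(N)N(c2ccc(S(N)(=O)=O)cc2)C2=C1C(=O)CCC2` – 0%
compound 2 `COc1ccc(C2C(C#N)=C(N)N(c3ccc(S(N)(=O)=O)cc3)C3=C2C(=O)CCC3)c2ccccc12` – 10%
compound 3 `Cc1ccoc1C1C(C#N)=C(N)N(c2ccc(S(N)(=O)=O)cc2)C2=C1C(=O)CCC2` – not yet measured

In a functional assay on Ehrlich cells (Mus musculus) for antiproliferative activity, read by trypan blue exclusion, with a stated time of 2 h, tested at 25 ug/mL (on this read-out lower numbers stand for a weaker effect and higher numbers for a stronger effect at the one concentration tested), compound 1 gives 0%, and compound 2 gives 10%; the step of a number 10 percentage points higher from compound 1 to compound 2 (within the scatter) lies within the scatter, so the two numbers cannot be told apart. Compound 3 differs from compound 1 by 3-methylfuran-2-yl in place of 2-methoxyphenyl on a saturated ring carbon. For the measured compounds named here, the only measured step that bears on this exchange of the group on the saturated ring carbon is a number 10 percentage points higher from compound 1 to compound 2 (within the scatter), which stayed within the scatter. For compound 3 the expected step is therefore a number 5 percentage points higher from compound 1 to compound 3 (within the scatter), nothing beyond the scatter. Compound 3 is estimated at 5%, with a range from 0% to 20%.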

Compound 3, a percentage reported as activity, at one concentration (the size of the read-out at that concentration, not a potency): 10%
Beside the measured number, compound 3's estimate is 5 percentage points below it; the range from low to high includes it.
By their numbers in this assay, from the lowest: compounds 1, 2 and 3 (each within the scatter of the next).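

In this assay, 3-methylfuran-2-yl on the saturated ring carbon gives a number 10 percentage points higher from compound 1 to compound 3 (within the scatter), and no change at the digits printed from compound 2 to compound 3 (within the scatter). Three aromatic groups of different ring type at this position, including now a five-membered ring with a hetero atom, therefore cannot be told apart. No supporting evidence bears on this result. As far as these compounds go, it remains open whether an amine, a carboxylic acid or a longer alkyl chain on this carbon would move the read-out beyond the scatter. Also open, from the compounds shown here alone, is whether replacing the 4-sulfamoylphenyl group on the ring nitrogen would do so.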